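The source may report more compounds than this note shows. Statements on the series, on what has been measured and on what is new or still open speak of the compounds shown alone.

Measured so far in a functional assay on A549 cells (Homo sapiens) for cytotoxicity, read by XTT assay, with a stated time of 24 h; a higher number here means a weaker inhibitor, a lower number a stronger inhibitor:
compound 1 `Fc1cc(F)cc(/C=N/NC(=S)Nc2cccc3ccccc23)c1` gives 500 ug/mL;
compound 2 `Fc1ccc(/C=N/NC(=S)Nc2cccc3ccccc23)cc1F` gives 125 ug/mL.

Going by the values given here, compound 2 stands at the lower of the two numbers in this assay, the only step being a 4.0-fold lower number from compound 1 to compound 2 (0.60 log units; beyond the scatter). Compound 3 `Fc1ccc(F)c(/C=N/NC(=S)Nc2cccc3ccccc23)c1` is unmeasured; the change is 2,5-difluorophenyl in place of 3,4-difluorophenyl on a carbon with a double bond to nitrogen. Among the compounds with values here, the one measured step bears on it only loosely: moving fluorine positions on this ring has shifted this assay beyond the scatter, but no step tells the direction for the new pattern. A modest step, likely toward a higher number, is expected: a 2.0-fold higher number from compound 2 to compound 3 (0.30 log units; within the scatter). Compound 3 is estimated at 250 ug/mL, range 100 ug/mL to 500 ug/mL.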

Compound 3, half-maximal inhibitory concentration: 500 ug/mL
Compound 3: middle estimate off by 2.0-fold (0.30 log units), on the low side; the range from low to high includes it.
By their numbers in this assay, from the lowest: compound 2; then compounds 1 and 3 (each within the scatter of the next).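

In this assay, 2,5-difluorophenyl in place of 3,4-difluorophenyl gives a 4.0-fold higher number from compound 2 to compound 3 (0.60 log units; beyond the scatter), whereas 2,5-difluorophenyl in place of 3,5-difluorophenyl gives no change at the digits printed from compound 1 to compound 3 (within the scatter). On this carbon, the atoms stay the same and only the fluorine pattern changes, so 3,4-difluorophenyl is the one pattern of the three that stands apart. Nothing available accounts for this difference.

Open, as far as these compounds go, is whether this pattern keeps its edge against an unsubstituted phenyl, a single fluorine or a methoxy group at this place. Also open, from the compounds shown here alone, is whether a chlorine pair would follow the same order.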